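Varying the Substituent on the Aromatic Nitrogen

The source may report more compounds than this note shows. Statements on the series, on what has been measured and on what is new or still open speak of the compounds shown alone.

Compound 1, `CCCCn1ccc2cc(/C(C)=C/C(=O)Nc3ccccc3OCCCC(=O)O)ccc21`: in an assay on Prostate gland for inhibition of steroid 5-alpha-reductase (Rattus norvegicus) (on this read-out lower numbers stand for stronger inhibition and higher numbers for weaker inhibition), compound 1 gives 43 nM.
Compound 2, `CCCCC(CCCC)n1ccc2cc(/C(C)=C/C(=O)Nc3ccccc3OCCCC(=O)O)ccc21`: in this assay compound 2 gives 21 nM.

Within the data shown here, of the two numbers measured so far, compound 2 stands lowest; the only step, a 2.0-fold lower number from compound 1 to compound 2 (0.31 log units; beyond the scatter), is modest but beyond the scatter, and it comes from replacing butyl with 1-butylpentyl on the aromatic nitrogen.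

Compound 3, `C/C(=C\C(=O)Nc1ccccc1OCCCC(=O)O)c1ccc2c(ccn2Cc2ccc(F)cc2)c1`, is not yet measured in this assay. Its change from compound 2 is 4-fluorobenzyl in place of 1-butylpentyl on an aromatic nitrogen. Among the measured compounds shown here, the one measured step bears on it only indirectly: it shows that changing the group on this nitrogen between two alkyl chains moves the number by a 2.0-fold lower number from compound 1 to compound 2 (0.31 log units; beyond the scatter), and no measured pair shows what an aromatic ring in this place does. A step of similar or smaller size in either direction, or none beyond the scatter, is the reasonable expectation, with the uncertainty widened by the lack of precedent.

Compound 3 is therefore estimated to give 30 nM in this assay, with a range from 8 nM to 120 nM. This estimate amounts to an expected step of a 1.4-fold higher number from compound 2 to compound 3 (0.15 log units; within the scatter).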

Compound 3, half-maximal inhibitory concentration: 97 nM
The estimate for compound 3 lay 3.2-fold (0.51 log units) below the measured number; the range from low to high includes it.
By their numbers in this assay, from the lowest: compound 2; then compound 1; then compound 3.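

In this assay, among these compounds, placing an aromatic ring on this nitrogen produced the first upward step at this position (a 4.6-fold higher number from compound 2 to compound 3 (0.66 log units; beyond the scatter)). The 4-fluorobenzyl group also falls behind the plain butyl chain (a 2.3-fold higher number from compound 1 to compound 3 (0.35 log units; beyond the scatter)), so among these three compounds compound 3 stands highest, with both alkyl groups giving lower numbers. The position therefore responds in both directions, and a group carrying a six-membered aromatic ring was not tolerated as well here as either of the two chains without a ring. Nothing measured here accounts for this loss.

The compounds shown leave open whether the step belongs to the aromatic ring itself or to its fluorine, and a plain benzyl group or a cyclohexylmethyl group on this nitrogen would separate the two. They also leave open whether a phenyl ring held farther from the nitrogen on a longer chain, such as 3-phenylpropyl, would recover the numbers seen with the alkyl groups.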